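Cytotoxicity notes on a brominated diaryl ether series

The source may hold more compounds than are shown below. What is called first, only, known or untested is meant among the compounds shown, and "the series" means these compounds.

Measured so far in a functional assay on U-937 cells (Homo sapiens) for cytotoxicity, read by MTT assay, with a stated time of 24 h; a lower number here means a stronger inhibitor, a higher number a weaker inhibitor:
- compound 1, `CC(C)(C)OC(=O)N1CCCN(CCCCCOc2c(Br)cc(Br)cc2Oc2ccc(Br)cc2Br)CC1`, gives 39.5 ug/mL
- compound 2, `OCCOc1c(Br)cc(Br)cc1Oc1ccc(Br)cc1Br`, gives 34.5 ug/mL
- compound 3, `Brc1ccc(Oc2cc(Br)cc(Br)c2OCCCCCN2CCN(C/C=C/c3ccccc3)CC2)c(Br)c1`, gives 32.7 ug/mL

The three numbers sit close together. Compound 2 stands second highest of the three, and its distance to compound 3 as well as to compound 1 lies within the scatter, so no order among the three can be read from these values. The shared core carries an ether-linked side chain in all three; the chains differ widely in length and in what they end in, yet the half-maximal inhibitory concentration barely moves.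

The next compound, compound 4, `Brc1ccc(Oc2cc(Br)cc(Br)c2OCc2ccccc2)c(Br)c1`, is reached from compound 2 by a single change: phenyl in place of hydroxymethyl on a saturated chain carbon bound to an oxygen on an aromatic ring. The longer chains of compound 1 and compound 3 did not move the number beyond the scatter from compound 2, so a short benzyloxy chain in place of 2-hydroxyethoxy is expected to behave much the same. No directed step is expected from compound 2 to compound 4; the estimated step is a 1.1-fold lower number from compound 2 to compound 4 (0.03 log units; within the scatter), which is meant to lie within the scatter.

For compound 4 the estimate in this assay is 32 ug/mL, with a range from 15 ug/mL to 65 ug/mL.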

Compound 4, half-maximal inhibitory concentration: 29 ug/mL
The estimate for compound 4 lay 1.1-fold (0.04 log units) above the measured number; measured number inside the range.
By their numbers in this assay, from the lowest: compounds 4, 3, 2 and 1 (each within the scatter of the next).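

Going by these compounds alone, this is the first pair that differs in one place, and it gives a direct reading at this position: in this assay, phenyl in place of hydroxymethyl on a saturated chain carbon bound to an oxygen on an aromatic ring gives a 1.2-fold lower number from compound 2 to compound 4 (0.08 log units; within the scatter) and so no difference that can be read. The change removes the only hydrogen-bond donor and the only hydrogen-bond acceptor of the leaving group and brings in a six-membered aromatic ring, yet the two compounds are not separated in this assay. At this position, then, the hydroxyl end of the 2-hydroxyethoxy chain is not required for a number in this range, and a benzyloxy group serves equally well; no data at hand bear on why the change leaves the number in place.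

On these data alone, whether a carboxylic acid or a primary amine in place of hydroxymethyl, or a phenyl ring carrying a fluorine or a methoxy group, would produce a step beyond the scatter remains open. As far as these compounds go, all four compounds keep the same four bromines on the shared core, so the outcome of exchanging bromine for chlorine or hydrogen is also open, and it may prove more informative than further changes to the chain.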